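The source may report more compounds than this note shows. Statements on the series, on what has been measured and on what is new or still open speak of the compounds shown alone.

Values in an ADME assay on MT4 cells (Homo sapiens) for cytotoxicity, read by MTT assay, with a stated time of 96 h; a higher number here means that more compound is tolerated, a lower number that less compound is tolerated:
Compound 1 `NS(=O)(=O)c1ccc(N2N=C(c3ccccc3)CC2c2ccccc2Cl)cc1`: 44000 nM
Compound 2 `NS(=O)(=O)c1ccc(N2N=C(c3ccc(OCc4ccccc4)cc3)CC2c2ccccc2)cc1`: > 100000 nM (a limit)
Compound 3 `NS(=O)(=O)c1ccc(N2N=C(c3ccc(OCc4ccccc4)cc3)CC2c2ccc(F)cc2)cc1`: > 100000 nM (a limit)

Compound 3 gives only a limit, > 100000 nM, and so does one other compound: the limit of > 100000 nM in this assay, at which 2 of the 3 values shown sit. Compound 4 `NS(=O)(=O)c1ccc(N2N=C(c3ccc(OCc4ccccc4)cc3)CC2c2ccccc2Cl)cc1` carries 2-chlorophenyl in place of 4-fluorophenyl on a saturated ring carbon. Among the compounds with values here, the only measured step, a step that the two limits leave unreadable from compound 2 to compound 3, gives no size to carry over. The nearest evidence is compound 1, which already bears 2-chlorophenyl and gives a true number, 44000 nM, though it differs from compound 4 elsewhere. In this assay, a modest shift towards less compound tolerated is therefore expected. The estimated step is an at least 1.6-fold lower number from compound 3 to compound 4 (0.22 log units; that floor lies within the scatter). Compound 4 is estimated at 60000 nM, with an expected range of 25000 nM to 100000 nM.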

Compound 4, half-maximal cytotoxic concentration: 26000 nM
The estimate for compound 4 lay 2.3-fold (0.36 log units) above the measured number; low and high end bracket the measured number.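

In this assay, within the data shown here, 2-chlorophenyl in place of 4-fluorophenyl on the saturated ring carbon gives an at least 3.8-fold lower number from compound 3 to compound 4 (0.58 log units; beyond the scatter), the first readable change at this position. Among these compounds, the chloro as the only change gives an at least 3.8-fold lower number from compound 2 to compound 4 (0.58 log units; beyond the scatter), so the chloro alone accounts for a step beyond the scatter. Benzyloxy in place of hydrogen gives only a 1.7-fold lower number from compound 1 to compound 4 (0.23 log units; within the scatter), so that change does not separate the two compounds.

From the compounds shown here alone, the full size of the two larger steps stays open, since both start from a limit: the limit of > 100000 nM in this assay, at which 2 of the 4 values shown sit. Going by these compounds, whether methoxy or an amine in place of the chloro would also lower the number also stays open.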